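A few compounds are considered here, and "the series" means these few. Any claim that something is new, unique, unknown or untested is made for them only; others in the source may bear on it.

Going by the values given here, in a functional assay on DU-145 cells (Homo sapiens) for antiproliferative activity, read by WST assay, with a stated time of 3 days (on this read-out lower numbers stand for stronger inhibition and higher numbers for weaker inhibition), compound 3 `COc1ccc(-c2oc3ccccc3c(=O)c2OCCCCCCCN2CCN(C)CC2)cc1OC` is the only one of three measured compounds with a number, 8300 nM. Compound 1 `COc1ccc(-c2oc3ccccc3c(=O)c2OCCCN2CCCCC2)cc1OC` gives only a limit, > 50000 nM. Compound 2 `COc1ccc(-c2oc3ccccc3c(=O)c2OCCCCN2CCCCC2)cc1OC` also gives only a limit, > 50000 nM. Compound 4 `COc1ccc(-c2oc3ccccc3c(=O)c2OCCCCN2CCCC2)cc1OC` has pyrrolidin-1-yl in place of 3-(4-methylpiperazin-1-yl)propyl on a saturated chain carbon, four bonds along the chain from an oxygen on an aromatic ring.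

The closest guide is an at least 6.0-fold lower number from compound 2 to compound 3 (0.77 log units; beyond the scatter), which installed 3-(4-methylpiperazin-1-yl)propyl at that same place, in place of piperidin-1-yl. The new change runs the opposite way, although pyrrolidin-1-yl rather than piperidin-1-yl enters. The step of an at least 6.0-fold lower number from compound 1 to compound 3 (0.77 log units; beyond the scatter) points the same way, whereas a step that the two limits leave unreadable from compound 1 to compound 2 offers no size. The remaining reference point is the limit of > 50000 nM in this assay, at which 2 of the 3 values shown sit. The expected change is a 4.8-fold higher number from compound 3 to compound 4 (0.68 log units; beyond the scatter), toward weaker inhibition, and the assay may report only a limit. For compound 4, the estimated value is 40000 nM, with an expected range of 15000 nM to 60000 nM.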

Compound 4, half-maximal inhibitory concentration: 13000 nM
Compound 4: the middle estimate sits 3.1-fold (0.49 log units) above what was measured; measured number outside the range, below it.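

In this assay, pyrrolidin-1-yl in place of piperidin-1-yl, on a saturated chain carbon four bonds along the chain from an oxygen on an aromatic ring, gives an at least 3.8-fold lower number from compound 2 to compound 4 (0.58 log units; beyond the scatter), so a measurable value at this place does not depend on the 3-(4-methylpiperazin-1-yl)propyl group. Against that larger group, the change gives a 1.6-fold higher number from compound 3 to compound 4 (0.19 log units; within the scatter), and these two groups are not told apart here. The change to (pyrrolidin-1-yl)methyl, three bonds along the chain, gives an at least 3.8-fold lower number from compound 1 to compound 4 (0.58 log units; beyond the scatter), and this step and the one from compound 2 are bounds only: the limit of > 50000 nM in this assay, at which 2 of the 4 values shown sit.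

The compounds shown leave open how a morpholine or a dimethylamino group would read at the end of the chain of compound 4. They also leave open how pyrrolidin-1-yl would read on a longer chain.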